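Shifting the aryl thioether substituent from chloro to ester

A few compounds are considered here, and "the series" means these few. Any claim that something is new, unique, unknown or untested is made for them only; others in the source may bear on it.

The three measured compounds:
Compound 1 `OC[C@H]1O[C@@H](n2cnc3c(CSc4ccccc4Br)ncnc32)[C@H](O)[C@@H]1O` gives 2400 nM in an assay on isolated protein for binding affinity to Equilibrative nucleoside transporter 1 (Homo sapiens); a higher number here means a weaker inhibitor, a lower number a stronger inhibitor.
Compound 2 `OC[C@H]1O[C@@H](n2cnc3c(CSc4ccccc4Cl)ncnc32)[C@H](O)[C@@H]1O` gives 1780 nM in this assay.
Compound 3 `OC[C@H]1O[C@@H](n2cnc3c(CSc4cccc(Cl)c4)ncnc32)[C@H](O)[C@@H]1O` gives 282 nM in this assay.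

Compound 3 stands lowest of the three numbers in this assay: the gap is a 6.3-fold lower number from compound 2 to compound 3 (0.80 log units; beyond the scatter) and an 8.5-fold lower number from compound 1 to compound 3 (0.93 log units; beyond the scatter), both beyond the scatter. Compound 4 `COC(=O)c1ccc(SCc2ncnc3c2ncn3[C@@H]2O[C@H](CO)[C@@H](O)[C@H]2O)cc1` differs from compound 3 in one place: 4-(methoxycarbonyl)phenyl in place of 3-chlorophenyl on a sulfur. Among the compounds with values here, two measured steps bear on the aryl group on sulfur. Moving the chlorine around the ring gave an 8.5-fold lower number from compound 1 to compound 3 (0.93 log units; beyond the scatter) and a 6.3-fold lower number from compound 2 to compound 3 (0.80 log units; beyond the scatter), whereas exchanging one halogen for another gave only a 1.3-fold lower number from compound 1 to compound 2 (0.13 log units; within the scatter), within the scatter. Within the data shown here, neither step tests an ester, nor the substitution pattern of compound 4, so the direction is open; the one change in ring substitution that was measured moved the number modestly. He therefore expects compound 4 to land somewhat above compound 3, with wide uncertainty, a step of a 2.5-fold higher number from compound 3 to compound 4 (0.39 log units; beyond the scatter). His estimate for compound 4 in this assay is 700 nM, in the range 150 nM to 3500 nM.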

Compound 4, half-maximal inhibitory concentration: 813 nM
Beside the measured number, compound 4's estimate is 1.2-fold (0.06 log units) below it; the range from low to high includes it.
By their numbers in this assay, from the lowest: compound 3; then compound 4; then compounds 2 and 1 (each within the scatter of the next).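

Within the data shown here, the aryl group on sulfur need not carry a halogen: in this assay, the change to 4-(methoxycarbonyl)phenyl, the only group here with hydrogen-bond acceptors, gives a 2.2-fold lower number from compound 2 to compound 4 (0.34 log units; beyond the scatter) and a 3.0-fold lower number from compound 1 to compound 4 (0.47 log units; beyond the scatter). The same ester-bearing ring does not match 3-chlorophenyl, however, with a 2.9-fold higher number from compound 3 to compound 4 (0.46 log units; beyond the scatter), so this position accepts a larger, non-halogen group while 3-chlorophenyl keeps the lowest number of the four. Nothing available explains these differences.

Compound 4 differs from compound 3 in both the substituent and its place on the ring, so the effect of the ester cannot be separated from that of its location. Going by these compounds, how 3-(methoxycarbonyl)phenyl, 4-chlorophenyl, or a ring bearing a carboxylic acid or an amide would behave remains open.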